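Swapping methyl for bromo at the assay limit

The source may report more compounds than this note shows. Statements on the series, on what has been measured and on what is new or still open speak of the compounds shown alone.

In a functional assay on SW480 cells (Homo sapiens) for inhibition, read by luminescence and resazurin assay, with a stated time of 3 days (on this read-out higher numbers stand for weaker inhibition and lower numbers for stronger inhibition), compound 3 `CNc1ncc(C)c(NCc2ccc(NC(=O)c3ccc(F)cc3)cc2)n1` gives > 20000 nM, a limit and not a number. Compound 1 `CCNc1ncc(C)c(NCc2ccc(NC(=O)c3ccc(F)cc3)cc2)n1` gives > 20000 nM, also a limit. Among the compounds with values here, compound 2 `CCCNc1nc(NCc2ccc(C(=O)Nc3ccc(F)cc3)cc2)c2ccccc2n1` gives 1600 nM, the only true number so far. Compound 3 therefore stands at the limit of > 20000 nM in this assay, at which 2 of the 3 values shown sit.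

Compound 4 `CNc1ncc(Br)c(NCc2ccc(NC(=O)c3ccc(F)cc3)cc2)n1` differs from compound 3 by one change: bromo in place of methyl on an aromatic carbon. Within the data shown here, the one measured step, a step that the two limits leave unreadable from compound 1 to compound 3, changes a different place, so no measured step gives a size for this change. No clear shift in this assay is therefore expected, and a number no higher from compound 3 to compound 4 (the limit leaves the size open) is estimated to be small. For compound 4, the expected value is 20000 nM, with an estimated range of 7000 nM to 40000 nM.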

Compound 4, half-maximal inhibitory concentration: > 20000 nM
Compound 4: only a limit was reported; the forecaster's own chance of this, stated with the estimate: 65%; the middle value lies on the limit itself.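

Compound 3 and compound 4 both give only a limit and not a number, so no step between them can be read: the limit of > 20000 nM in this assay, at which 3 of the 4 values shown sit.

From the compounds shown here alone, whether bromo in place of methyl changes inhibition at all, and by how much, stays open.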